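This account rests on a few compounds, and the source may have more. Where it says the series, first, only, none or still open, it means among the compounds named here.

Of the compounds shown here, three built on a shared core have been tested in a functional assay on ACHN cells (Homo sapiens) for cytotoxicity, read by sulforhodamine B assay, with a stated time of 72 h; on this read-out higher numbers stand for weaker inhibition of growth and lower numbers for stronger inhibition of growth. Compound 1 `CCCC(=O)N1c2ccccc2CCC1C(=O)Nc1cc(C(F)(F)F)cc(C(F)(F)F)c1` gives 13900 nM. Compound 3 `COc1ccc(NC(=O)C2CCc3ccccc3N2)cc1` gives 38000 nM. Compound 2 `O=C(Nc1ccc(O)cc1)C1CCc2ccccc2N1` reaches only a limit of the assay, > 100000 nM, and no number. Of the two numbers shown, compound 1 has the lower one and compound 3 the other. Among the measured compounds shown here, the single measured step, an at least 2.6-fold lower number from compound 2 to compound 3 (0.42 log units; beyond the scatter), starts from the limit of > 100000 nM in this assay, at which 1 of the 3 values shown sits, and is known only as a minimum.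

Compound 4 `O=C(Nc1cc(C(F)(F)F)cc(C(F)(F)F)c1)C1CCc2ccccc2N1C(=O)c1ccccc1` has not yet been measured. It differs from compound 1 by phenyl in place of propyl on a carbonyl carbon. For the measured compounds named here, no measured step touches this part of the molecule: the step from compound 2 to compound 3 changes a group on an oxygen on an aromatic ring, not the group on the carbonyl carbon whose other neighbour is the amide-type nitrogen in a ring. Going by the values given here, there is thus nothing among the measured compounds to say that the exchange should move the number in either direction beyond the scatter. The step of a 1.2-fold lower number from compound 1 to compound 4 (0.06 log units; within the scatter) is therefore expected to be small. The estimate for compound 4 is 12000 nM, with a range from 3500 nM to 45000 nM.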

Compound 4, concentration for 50% growth inhibition: 2920 nM
Compound 4: the middle estimate sits 4.1-fold (0.61 log units) above what was measured; measured number outside the range, below it.
By their numbers in this assay, from the lowest: compound 4; then compound 1; then compound 3. At a limit, above all of these: compound 2.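

In this assay, the group on a carbonyl carbon whose other neighbour is the amide-type nitrogen in a ring proves able to move the read-out: phenyl in place of propyl gives a 4.8-fold lower number from compound 1 to compound 4 (0.68 log units; beyond the scatter) and so lies beyond the usual scatter. Among the compounds shown here, this is the first measured step at this position, since the only earlier step concerned a group on an oxygen on an aromatic ring. Nothing measured here accounts for the size or direction of this step.

The exchange replaces a chain with no ring by a six-membered aromatic ring and also brings more heavy atoms, so these two differences cannot be separated: a cyclohexyl group, which has a ring of the same size but is not aromatic, or a longer chain such as hexyl, would be needed to pull them apart. On these data alone, it also remains open whether a benzoyl group carrying a substituent, such as a methoxy group or a chlorine atom, or a pyridine ring in place of phenyl, would lower the number further or raise it again.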